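The source may hold more compounds than are shown below. What is called first, only, known or untested is meant among the compounds shown, and "the series" means these compounds.

Measured in an ADME assay on HEK293 cells (Homo sapiens) for cytotoxicity, read by luminescence, with a stated time of 72 h; a lower number here means that less compound is needed, a higher number that more compound is needed for the effect (each entry is a limit of the assay, not a number):

- compound 1, `CCOC(=O)c1c(-c2cccc(OC)c2)[nH]c2cc(OC)ccc2c1=O`: > 22000 nM
- compound 2, `CCOC(=O)c1c(-c2cccc(OC)c2)[nH]c2cc(OC(F)(F)F)ccc2c1=O`: > 22000 nM
- compound 3, `CCOC(=O)c1c(-c2cccc(OC(F)(F)F)c2)[nH]c2cc(OC(F)(F)F)ccc2c1=O`: > 22000 nM

Compound 2 is known only by its limit of > 22000 nM, and it has no measured number. The two further compounds are also known only by limits, so the whole series stands at the limit of > 22000 nM in this assay, at which 3 of the 3 values shown sit.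

The step of interest leads to compound 4, `CCOC(=O)c1c(-c2cccc(OC)c2)[nH]c2cc(SC)ccc2c1=O`, which has methylsulfanyl in place of trifluoromethoxy on an aromatic carbon of the shared core (methylsulfanyl in place of trifluoromethoxy on an aromatic carbon). The group sits meta to a fused ring and para to a fused ring. Within the data shown here, no measured step makes this exact exchange. The nearest evidence is a step that the two limits leave unreadable from compound 1 to compound 2, together with a step that the two limits leave unreadable from compound 2 to compound 3. Both replace methyl with trifluoromethyl on an oxygen on an aromatic ring, and neither has a readable size. They therefore give no direction for the change, and no effect beyond the scatter is expected in this assay. The expected result is a number no higher from compound 2 to compound 4 (the limit leaves the size open), and another limit is the most likely report. For compound 4 the estimated value is 22000 nM, with an expected range from 11000 nM to 44000 nM.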

Compound 4, half-maximal effective concentration: > 22000 nM
Compound 4: only a limit was reported; the forecaster's own chance of this, stated with the estimate: 85%; the middle value lies on the limit itself.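

The steps to compound 4 from compound 1 and from compound 2 cannot be read, as all three compounds are reported only as limits. The compounds shown leave open whether methylsulfanyl, methoxy or trifluoromethoxy on this aromatic carbon makes any difference to the cytotoxicity read-out, and at what concentration any compound reaches its half-maximal effect: the limit of > 22000 nM in this assay, at which 4 of the 4 values shown sit.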